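Taking Away the Methoxy: From Compound 2 to Compound 3

The compounds below may be only part of what the source reports. "The series", "measured", "known", "first", "only" and "open" are said of these compounds alone.

Compound 1 `Cc1ccc(NC(=O)NS(=O)(=O)c2ccc3occc3c2)cc1`: 84%
Compound 2 `COc1cc(S(=O)(=O)NC(=O)Nc2ccc(Cl)cc2)cc2ccoc12`: 51%

Of the compounds shown here, two have been measured in a functional assay on the whole organism (Mus musculus) for inhibition, at a dose of 150 mg/kg by the oral route; a higher number here means more inhibition at the dose given (going by the name of the read-out), a lower number less inhibition. Compound 1 gives 84% in this assay, and compound 2 gives 51%. Compound 2 thus stands lowest of the two numbers, and its nearest neighbour, compound 1, lies above it by a distance beyond the usual scatter. Within the data shown here, compound 1 and compound 2 differ in more than one place, so no single step between measured compounds is available. The unmeasured compound 3 `O=C(Nc1ccc(Cl)cc1)NS(=O)(=O)c1ccc2occc2c1` is reached from compound 2 by one change: hydrogen in place of methoxy on an aromatic carbon Since compound 1 gives 84% without a methoxy, a rise for compound 3 is expected, though the other difference between compound 1 and compound 2 leaves this uncertain. The expected step is a number 19 percentage points higher from compound 2 to compound 3 (beyond the scatter), upward and probably beyond the scatter. For compound 3 the estimate is 70%, within a range from 45% to 90%.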

Compound 3, a percentage reported as inhibition, in the whole organism at one dose (the size of the read-out at that dose, not a potency): 100%
Estimate against measurement, compound 3: 30 percentage points below; measured number above the stated range.
By their numbers in this assay, from the lowest: compound 2; then compound 1; then compound 3.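

In this assay, among these compounds, this is the first comparison at this position that changes only one place, and it shows that the methoxy on the aromatic carbon is not needed for the inhibition: hydrogen in its place gives a number 49 percentage points higher from compound 2 to compound 3 (beyond the scatter) as a large step. Chloro in place of methyl on an aromatic carbon gives a number 16 percentage points higher from compound 1 to compound 3 (beyond the scatter) as a modest one, so the loss of the methoxy carries the larger change of the two. No measurement shown here accounts for the size of either step.

As far as these compounds go, whether a hydroxyl, a fluoro or an amine at this position would keep the inhibition of compound 3 remains open. Also open, from the compounds shown here alone, is whether the methoxy would have a step of similar size with methyl in place of chloro.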